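A few compounds are considered here, and "the series" means these few. Any claim that something is new, unique, unknown or untested is made for them only; others in the source may bear on it.

- compound 1 `Cc1ccc(N(C)S(=O)(=O)C2CC3OC2C(c2ccc(NC(=O)CCCCCCC(=O)O)cc2)=C3c2ccc(O)cc2)cc1`: > 100000 nM
- compound 2 `CN(c1ccc(Cl)cc1)S(=O)(=O)C1CC2OC1C(c1ccc(NC(=O)CCCCCCC(=O)O)cc1)=C2c1ccc(O)cc1`: 72100 nM

Both compounds were tested in a functional assay on DU-145 cells (Homo sapiens) for antiproliferative activity, read by MTT assay, with a stated time of 72 h; on this read-out higher numbers stand for weaker inhibition and lower numbers for stronger inhibition. Going by the values given here, there, compound 2 gives 72100 nM, the only actual number so far. Compound 1 reads > 100000 nM, which is a limit of the assay and not a number. This is the limit of > 100000 nM in this assay, at which 1 of the 2 values shown sits.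

The next compound is compound 3 `CCN(c1ccc(C)cc1)S(=O)(=O)C1CC2OC1C(c1ccc(NC(=O)CCCCCCC(=O)O)cc1)=C2c1ccc(O)cc1`, in which ethyl(4-methylphenyl)amino stands in place of (4-chlorophenyl)(methyl)amino on a sulfonyl sulfur: ethyl(4-methylphenyl)amino in place of (4-chlorophenyl)(methyl)amino on a sulfonyl sulfur. Among the compounds with values here, the one measured step that bears on this change is an at least 1.3-fold lower number from compound 1 to compound 2 (0.14 log units; that floor lies within the scatter). That step swaps chloro in place of methyl on an aromatic carbon, so it touches the group that leaves compound 2. Within the data shown here, no measured step covers the ethyl part of the change.

In this assay, among the measured compounds shown here, no shift beyond the scatter is expected, because an at least 1.3-fold lower number from compound 1 to compound 2 (0.14 log units; that floor lies within the scatter) is the only guide and its floor lies within that scatter. The expected change is a 1.2-fold higher number from compound 2 to compound 3 (0.07 log units; within the scatter). For compound 3 the estimated value is 85000 nM, with an expected range from 40000 nM to 170000 nM.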

Compound 3, half-maximal inhibitory concentration: 53500 nM
Beside the measured number, compound 3's estimate is 1.6-fold (0.20 log units) above it; the range from low to high includes it.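

In this assay, the exchange of (4-chlorophenyl)(methyl)amino for ethyl(4-methylphenyl)amino on the sulfonyl sulfur gives a 1.3-fold lower number from compound 2 to compound 3 (0.13 log units; within the scatter), so this larger change at the sulfonyl sulfur, which alters two parts of the group at once, cannot be told from the scatter. Going by these compounds alone, the ethyl part, which no earlier step covered, can now be read alone, since methyl in place of hydrogen on a saturated chain carbon bound to a sulfonamide nitrogen gives an at least 1.8-fold lower number from compound 1 to compound 3 (0.27 log units; that floor lies within the scatter). This step offers only a floor, because it starts from compound 1, whose reading is a limit and not a number: the limit of > 100000 nM in this assay, at which 1 of the 3 values shown sits.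

The compounds shown leave open how a propyl chain or a plain hydrogen on the sulfonamide nitrogen would read, and how a methoxy or fluoro group on the aromatic ring would compare with the chloro and methyl groups. They also leave open whether a hydroxamic acid in place of the carboxylic acid, which all three compounds carry, would move the numbers beyond the scatter.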